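Methoxy in Place of Chloro: A Matched Pair

The compounds below may be only part of what the source reports. "The series", "measured", "known", "first", "only" and "open" are said of these compounds alone.

Measured compounds:
compound 1, `O=C(Nc1cc(-c2ccccc2)[nH]n1)c1ccc(Cl)nc1`: 19000 nM
compound 2, `COc1ccc(C(=O)Nc2cc(-c3ccccc3)[nH]n2)cn1`: 24700 nM
compound 3, `Cc1ccc(-c2cc(NC(=O)c3cccnc3Cl)n[nH]2)cc1`: 15800 nM

Of the compounds shown here, three have been measured in a functional assay on WM1361 cells (Homo sapiens) for antiproliferative activity, read by MTT assay, with a stated time of 48 h; a higher number here means a weaker inhibitor, a lower number a stronger inhibitor. In this assay compound 1 gives 19000 nM, compound 2 gives 24700 nM and compound 3 gives 15800 nM. Compound 2 arises from compound 1 through a single change, (methoxy in place of chloro on an aromatic carbon), and the step it made was a 1.3-fold higher number from compound 1 to compound 2 (0.11 log units; within the scatter). The values of compound 3 and compound 1 lie within the scatter of each other, and so do those of compound 3 and compound 2. How the core of compound 3 differs from the core of compound 1 is not broken down here.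

Compound 4, `COc1ncccc1C(=O)Nc1cc(-c2ccc(C)cc2)[nH]n1`, has not yet been measured. It arises from compound 3 through the same kind of change, (methoxy in place of chloro on an aromatic carbon). The surroundings of the place are not identical: in the change from compound 1 to compound 2 the carbon is para to a large group, while in the change from compound 3 to compound 4 it is ortho to a large group.

The step from compound 3 to compound 4 is expected to be of a similar size to the earlier one, a 1.3-fold higher number from compound 3 to compound 4 (0.10 log units; within the scatter), because a 1.3-fold higher number from compound 1 to compound 2 (0.11 log units; within the scatter) stayed within the scatter when the same kind of change was made. Compound 4 is therefore expected to give about 20000 nM in this assay, with an estimated range from 10000 nM to 40000 nM.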

Compound 4, half-maximal inhibitory concentration: 25800 nM
Compound 4: the middle estimate sits 1.3-fold (0.11 log units) below what was measured; low and high end bracket the measured number.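

In this assay, methoxy in place of chloro on an aromatic carbon, here ortho to a large group and next to the ring nitrogen, gave a small step (a 1.6-fold higher number from compound 3 to compound 4 (0.21 log units; within the scatter)). Set beside the earlier step, it shows that the change behaved alike on both cores, with neither step leaving the scatter and no measurable difference between them: the same change on two cores in this assay, a 1.3-fold higher number (0.11 log units; within the scatter) from compound 1 to compound 2 and a 1.6-fold higher number (0.21 log units; within the scatter) from compound 3 to compound 4, 1.3-fold (0.10 log units) apart, within the scatter of two such steps. For the compounds shown here, this agreement rests on only two matched pairs, however; it shows neither that the steps are real effects rather than scatter nor that chloro and methoxy would be interchangeable on other cores, and it gives no reason for the result.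

The compounds shown leave open whether a different group on the same carbon, such as an amine, a carboxylic acid or a longer chain like butoxy, would produce a step beyond the scatter in this assay. They also leave open whether the same exchange would stay this small on a core carrying other groups on its outer benzene ring, such as a hydroxyl or a fluoro group, in place of the hydrogen or methyl seen in these four compounds.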